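A few compounds are considered here, and "the series" means these few. Any claim that something is new, unique, unknown or untested is made for them only; others in the source may bear on it.

Among the measured compounds shown here, compound 1 `CCCC(O)CC(=O)O[C@H](CC=C(C)C)C1=CC(=O)c2c(O)ccc(O)c2C1=O` is one of two compounds measured in a functional assay on HeLa cells (Homo sapiens) for cytotoxicity, read by MTT assay; on this read-out lower numbers stand for stronger inhibition and higher numbers for weaker inhibition. In this assay, for the measured compounds named here, compound 1 gives 59300 nM, and the only other measured compound, compound 2 `COC(C)CO[C@H](CC=C(C)C)C1=CC(=O)c2c(O)ccc(O)c2C1=O`, gives 53400 nM; the two numbers lie within the usual scatter of each other, and the single measured step, a 1.1-fold lower number from compound 1 to compound 2 (0.05 log units; within the scatter), showed no change beyond that scatter.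

Compound 3 `CCCCCCC(C)(O)CC(=O)O[C@H](CC=C(C)C)C1=CC(=O)c2c(O)ccc(O)c2C1=O` differs from compound 1 by the exchange (1-hydroxy-1-methylheptyl in place of 1-hydroxybutyl on a saturated chain carbon bound to a carbonyl carbon). Going by the values given here, no measured step concerns this part of the molecule: the step from compound 1 to compound 2 replaces the whole ester side by an ether and so bears only loosely on a change within the acyl chain. What the two measured numbers show is that both compounds sit close together in this assay, so the expectation for compound 3 is a step near zero, a 1.2-fold lower number from compound 1 to compound 3 (0.07 log units; within the scatter), with wide uncertainty in either direction. Compound 3 is therefore estimated at 50000 nM, expected to fall between 18000 nM and 140000 nM.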

Compound 3, half-maximal inhibitory concentration: > 100000 nM
Compound 3: a limit, no number; the forecaster's own chance of this, stated with the estimate: 10%; at least 2.0-fold (0.30 log units) between middle value and limit.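

Compound 3 is the only compound shown with a change within the acyl chain, with 1-hydroxy-1-methylheptyl in place of 1-hydroxybutyl on a saturated chain carbon bound to a carbonyl carbon. In this assay compound 3 gives > 100000 nM, which is a limit of the assay and not a number. The comparison therefore yields only a floor, an at least 1.6-fold higher number from compound 1 to compound 3 (0.22 log units; that floor lies within the scatter), so this change cannot be given a size, and what is known of its result is this: the limit of > 100000 nM in this assay, at which 1 of the 3 values shown sits.

The enlarged chain and the extra methyl arrive together in 1-hydroxy-1-methylheptyl, and the compounds shown do not separate them. On these data alone, how 1-hydroxyheptyl, or an amine in place of the hydroxyl group of 1-hydroxybutyl, would read in this assay stays open.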